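The source may report more compounds than this note shows. Statements on the series, on what has been measured and on what is new or still open speak of the compounds shown alone.

Among the measured compounds shown here, in a functional assay on the whole organism with Scenedesmus acutus as the target (a lower number here means a stronger inhibitor, a higher number a weaker inhibitor), compound 1 (`CCOC(=O)c1cc(N2C(=O)C3=C(CCCC3)C2=O)c(F)cc1Cl`) gives 100 nM and holds the lower of the two numbers known so far. Compound 2 (`CCOC(=O)c1cc(N2C(=O)C3=C(CCCC3)C2=O)ccc1Cl`) gives 1380 nM in the same test. Compound 3 (`CC(C)COC(=O)c1cc(N2C(=O)C3=C(CCCC3)C2=O)c(F)cc1Cl`) keeps the core of compound 1 and changes only one chain: isopropyl in place of methyl on a saturated chain carbon bound to an oxygen next to a carbonyl group, which also reads as ethoxycarbonyl to isobutoxycarbonyl. For the measured compounds named here, the one measured step, a 14-fold higher number from compound 1 to compound 2 (1.14 log units; beyond the scatter), is large, but it concerns hydrogen in place of fluoro on an aromatic carbon. Going by the values given here, no measured step touches this chain, so the data give no direct size for the change. With compound 1 at 100 nM as the only anchor, little movement is expected in this assay, and a slightly higher number is only a tentative direction. The expected move is a 1.5-fold higher number from compound 1 to compound 3 (0.18 log units; within the scatter) and would stay within the scatter. The estimate for compound 3 is 150 nM, with 40 nM to 500 nM as its expected range.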

Compound 3, half-maximal inhibitory concentration: 33.1 nM
Beside the measured number, compound 3's estimate is 4.5-fold (0.66 log units) above it; the whole stated range lies above it.
By their numbers in this assay, from the lowest: compound 3; then compound 1; then compound 2.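

In this assay the change from ethoxycarbonyl to isobutoxycarbonyl gives a 3.0-fold lower number from compound 1 to compound 3 (0.48 log units; beyond the scatter) and so provides the first measured size for this chain. It shows that this place in the molecule is not silent: isopropyl in place of methyl on a saturated chain carbon bound to an oxygen next to a carbonyl group moves the number beyond the scatter, though the step is smaller than a 14-fold higher number from compound 1 to compound 2 (1.14 log units; beyond the scatter) at the other place. Nothing measured here bears on why the number falls with this change.

Going by these compounds, whether the branched isobutyl chain itself matters, or only its length, stays open, and a straight butyl chain or a free carboxylic acid in this place would test that. Also open, on these data alone, is whether the same chain change would bring a similar step on compound 2, which carries hydrogen in place of fluoro.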